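Ring nitrogen substituents: from compound 3 to compound 4

This account rests on a few compounds, and the source may have more. Where it says the series, first, only, none or still open, it means among the compounds named here.

Three compounds share one core and differ only in the group on an amine nitrogen in a ring: compound 1 `Cc1ccc(-c2c3c(nc(C)c2[C@H](OC(C)(C)C)C(=O)O)CCN(C(=O)OCc2ccccc2)C3)cc1` carries benzyloxycarbonyl, compound 2 `Cc1ccc(-c2c3c(nc(C)c2[C@H](OC(C)(C)C)C(=O)O)CCN(c2ccccc2)C3)cc1` phenyl and compound 3 `Cc1ccc(-c2c3c(nc(C)c2[C@H](OC(C)(C)C)C(=O)O)CCN(Cc2ccccc2)C3)cc1` benzyl. In an ADME assay on MT2 cells (Homo sapiens) for cytotoxicity, read by XTT assay, with a stated time of 4 days (on this read-out higher numbers stand for lower toxicity in this test and lower numbers for higher toxicity in this test), compound 1 gives > 40000 nM as a limit. Compound 2 gives > 40000 nM as a limit too. Compound 3 gives > 40000 nM as a limit as well, so it has no number of its own and stands level with the other two. The whole record so far is the limit of > 40000 nM in this assay, at which 3 of the 3 values shown sit, and it sets no direction.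

The next compound is compound 4 `Cc1ccc(-c2c3c(nc(C)c2[C@H](OC(C)(C)C)C(=O)O)CCN(C(=O)CCc2ccccc2)C3)cc1` with phenethylcarbonyl in place of benzyl on an amine nitrogen in a ring. Among the measured compounds shown here, the steps that bear on this change are those at the same nitrogen: a step that the two limits leave unreadable from compound 1 to compound 3 and a step that the two limits leave unreadable from compound 2 to compound 3 and a step that the two limits leave unreadable from compound 1 to compound 2 and none of them has a size that can be read. All three groups end at the same limit, so no step beyond the scatter is expected in this assay and no direction can be named. The estimated step of a number no higher from compound 3 to compound 4 (the limit leaves the size open) is expected to stay within the scatter. Compound 4 is estimated at 40000 nM with an expected range from 20000 nM to 60000 nM and will probably be reported only as a limit.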

Compound 4, half-maximal cytotoxic concentration: > 40000 nM
Compound 4 gave a limit, no number; the forecaster's own chance of this, stated with the estimate: 85%; the middle value lies on the limit itself.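

In this assay compound 4 gives > 40000 nM as a limit, not a number. Its steps to compound 1, compound 2 and compound 3 cannot be read, and the record remains: the limit of > 40000 nM in this assay, at which 4 of the 4 values shown sit. The compounds shown leave open whether any group on the amine nitrogen in the ring shifts this read-out at all.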